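This account rests on a few compounds, and the source may have more. Where it says the series, first, only, none or still open, it means among the compounds named here.

Measured so far:
compound 1 `Cc1cccc(C(=O)/C=C/c2cc(/C=C/C(=O)NO)n(C)c2)c1`, 2500 nM in an assay on isolated protein for inhibition of histone deacetylase HD1B (Zea mays); a higher number here means a weaker inhibitor, a lower number a stronger inhibitor
compound 2 `Cn1cc(/C=C/C(=O)c2cccs2)cc1/C=C/C(=O)NO`, 25800 nM in this assay

Among the measured compounds shown here, compound 2 holds the higher of the two numbers in this assay; its nearest neighbour is compound 1, and the one step between them, a 10-fold higher number from compound 1 to compound 2 (1.01 log units; beyond the scatter), lies beyond the scatter. Compound 3 `Cn1cc(/C=C/C(=O)c2ccco2)cc1/C=C/C(=O)NO` is not yet measured. The change from compound 2 to compound 3 is furan-2-yl in place of thiophen-2-yl on a carbonyl carbon. For the measured compounds named here, no measured step covers this exchange: the single step in hand, a 10-fold higher number from compound 1 to compound 2 (1.01 log units; beyond the scatter), replaces 3-methylphenyl by thiophen-2-yl and says nothing about a swap between two five-membered aromatic rings that differ only in the hetero atom. Going by the values given here, with nothing pointing either way, no step beyond the scatter is expected for a 1.0-fold lower number from compound 2 to compound 3 (0.01 log units; within the scatter), though the one known step at this position was large, so the range is kept wide. Compound 3 is therefore estimated at 25000 nM, within 8000 nM to 80000 nM.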

Compound 3, half-maximal inhibitory concentration: 19700 nM
Compound 3: middle estimate off by 1.3-fold (0.10 log units), on the high side; measured number inside the range.
By their numbers in this assay, from the lowest: compound 1; then compounds 3 and 2 (each within the scatter of the next).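

In this assay, the two five-membered aromatic rings on the carbonyl carbon, which differ only in the hetero atom, are not told apart: a 1.3-fold lower number from compound 2 to compound 3 (0.12 log units; within the scatter) stays within the scatter. The gap to the 3-methylphenyl compound is therefore not peculiar to thiophen-2-yl, as furan-2-yl also shows it, with a 7.9-fold higher number from compound 1 to compound 3 (0.90 log units; beyond the scatter) standing alongside a 10-fold higher number from compound 1 to compound 2 (1.01 log units; beyond the scatter), and among these three compounds none goes against this. No measured evidence bears on what lies behind these results.

Open, going by these compounds, is how a plain phenyl on the same carbonyl carbon would compare, so the contributions of the methyl group and of the ring it sits on to the lower number of compound 1 cannot yet be separated. Also open, on these data alone, is how a phenyl carrying an amine or a carboxylic acid would compare.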